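Removing the Pyridyl Arm from an Oxazole Ketone

The source may report more compounds than this note shows. Statements on the series, on what has been measured and on what is new or still open speak of the compounds shown alone.

Compound 1: `CCCCCCCC/C=C\CCCCCCC(=O)c1ccccn1` — > 100000 nM
Compound 2: `CCCCCCCC/C=C\CCCCCCC(=O)c1nc2cccnc2o1` — 11 nM
Compound 3: `CCCCCCCC/C=C\CCCCCCC(=O)c1ncc(-c2ccccn2)o1` — 18 nM

In an assay on isolated protein for inhibition of Fatty-acid amide hydrolase 1 (Homo sapiens) (a higher number here means a weaker inhibitor, a lower number a stronger inhibitor), compound 1 reaches only a limit of the assay, > 100000 nM. Compound 2 gives 11 nM. Compound 3 gives 18 nM, the higher of the two numbers, yet within the scatter of compound 2, so the two are not told apart. Among the compounds with values here, the only measured step is an at least 9000-fold lower number from compound 1 to compound 2 (3.95 log units; beyond the scatter); compound 1 sits at the limit of > 100000 nM in this assay, at which 1 of the 3 values shown sits, so the true size of that step is not known.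

Compound 4, `CCCCCCCC/C=C\CCCCCCC(=O)c1ncco1`, differs from compound 3 by hydrogen in place of pyridin-2-yl on an aromatic carbon. Within the data shown here, no measured step removes a group from the five-membered ring, so the only guidance is that compound 2 and compound 3 both keep a second aromatic ring on the core and both bind strongly, while compound 1, lacking the five-membered ring altogether, does not. Compound 4 keeps the five-membered ring but loses the second ring; a weaker binder than compound 3 is therefore expected, by a step of a 33-fold higher number from compound 3 to compound 4 (1.52 log units; beyond the scatter). Compound 4 is estimated at 600 nM, within 150 nM to 3000 nM.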

Compound 4, inhibition constant: 17 nM
Compound 4: the middle estimate sits 35-fold (1.55 log units) above what was measured, outside the stated range (below it).
By their numbers in this assay, from the lowest: compounds 2, 4 and 3 (each within the scatter of the next). At a limit, above all of these: compound 1.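

Taking pyridin-2-yl off the aromatic carbon next to the ring oxygen gives a 1.1-fold lower number from compound 3 to compound 4 (0.02 log units; within the scatter) in this assay, so this substituent adds nothing that can be detected at this position. Replacing the larger group of compound 2 with 1,3-oxazol-2-yl on the carbonyl carbon gives a 1.5-fold higher number from compound 2 to compound 4 (0.19 log units; within the scatter), so among these compounds strong binding does not require a second aromatic ring. Putting 1,3-oxazol-2-yl in place of pyridin-2-yl on the carbonyl carbon gives an at least 5800-fold lower number from compound 1 to compound 4 (3.76 log units; beyond the scatter), a step whose true size is unknown, as it is set by a limit of the assay: the limit of > 100000 nM in this assay, at which 1 of the 4 values shown sits.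

From the compounds shown here alone, it remains open whether a carboxylic acid or a phenyl group on that aromatic carbon would move the number beyond the scatter of compound 4. Going by these compounds, how a shorter chain, or one without its double bond, would compare with compound 4 also stays open.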